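The source may report more compounds than this note shows. Statements on the series, on what has been measured and on what is new or still open speak of the compounds shown alone.

Within the data shown here, compound 1 `FC(F)(F)c1ccc(Nc2ncnc3sc(Nc4ccccc4Cl)nc23)cc1` is one of three compounds measured in a functional assay on HEK293 cells for antagonist activity at transient receptor potential cation channel subfamily V member 1 (Homo sapiens), read by calcium flux (on this read-out lower numbers stand for stronger inhibition and higher numbers for weaker inhibition), where compound 1 gives 64 nM. Compound 3 `CCN(CC)c1nc(Nc2ccc(C(F)(F)F)cc2)c2nc(Nc3c(Cl)cccc3Cl)sc2n1` gives 48 nM, a number within the usual scatter of that of compound 1, so the two cannot be ranked. Compound 2 `CSc1nc(Nc2ccc(C(F)(F)F)c(Cl)c2)c2nc(Nc3c(Cl)cccc3Cl)sc2n1` gives 224 nM, a higher number than compound 1 by more than the scatter. Compound 4 `OCc1cc(Cl)c(Nc2nc3c(Nc4ccc(C(F)(F)F)cc4)ncnc3s2)c(Cl)c1` differs from compound 1 in one place: 2,6-dichloro-4-(hydroxymethyl)phenyl in place of 2-chlorophenyl on a nitrogen on an aromatic ring. Among the measured compounds shown here, compounds 2 and 3 differ from compound 1 in more than one place, so no single step shows what this change alone does. The expected step from compound 1 to compound 4 in this assay is therefore small, a 1.2-fold higher number from compound 1 to compound 4 (0.07 log units; within the scatter), with no clear direction. Compound 4 is estimated at 75 nM, within a range from 25 nM to 220 nM.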

Compound 4, half-maximal inhibitory concentration: 1 nM
Compound 4: the middle estimate sits 75-fold (1.88 log units) above what was measured; measured number outside the range, below it.
By their numbers in this assay, from the lowest: compound 4; then compounds 3 and 1 (each within the scatter of the next); then compound 2.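

The aryl group on this nitrogen is not a passive part of the structure: replacing 2-chlorophenyl with 2,6-dichloro-4-(hydroxymethyl)phenyl on the shared core produces a large gain in inhibition (a 64-fold lower number from compound 1 to compound 4 (1.81 log units; beyond the scatter)). This is the first single change shown here whose effect can be read directly, and it shows that this one position can shift the result far beyond the scatter.

As far as these compounds go, the change adds a chlorine and a hydroxymethyl group together, so their separate contributions remain open, as does the outcome with a carboxylic acid or an amine in place of the hydroxymethyl. No measurement available here explains why the step is so large.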